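Carboxy in Place of Methoxy: Expected Vero Cytotoxicity

The source may hold more compounds than are shown below. What is called first, only, known or untested is meant among the compounds shown, and "the series" means these compounds.

Two compounds have so far been examined in an ADME assay on Vero cells (Chlorocebus sabaeus) for cytotoxicity, read by MTT assay, with a stated time of 72 h; on this read-out lower numbers stand for stronger inhibition and higher numbers for weaker inhibition. Compound 1 `O=C(c1ccncc1)N1N=C(c2cc3ccccc3o2)CC1c1ccccc1[N+](=O)[O-]` reaches only the limit of the assay, reported as > 245000 nM. Compound 2 `CCn1cc(C(=O)N2N=C(c3cc4ccccc4o3)CC2c2ccccc2OC)c(=O)c2ccc(C)nc21` likewise stops at a limit, reported as > 187000 nM. Among the compounds with values here, compound 2 therefore stands at a limit rather than at a number, and the one further value shown is a limit too, so no ordering of the two can be read from them (the limit of > 187000 nM in this assay, at which 1 of the 2 values shown sits).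

Within the data shown here, no step between measured compounds is available here. Compound 3 `CCn1cc(C(=O)N2N=C(c3cc4ccccc4o3)CC2c2ccccc2C(=O)O)c(=O)c2ccc(C)nc21` differs from compound 2 by carboxy in place of methoxy on an aromatic carbon. Because compound 2 gives only a limit in this assay > 187000 nM, there is no number from which a direction could be taken. The step that the limit leaves unreadable from compound 2 to compound 3 is expected to be none beyond the scatter. Compound 3 is accordingly estimated at 250000 nM in this assay, within 100000 nM to 1000000 nM, most probably again reported only as a limit.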

Compound 3, half-maximal inhibitory concentration: > 196000 nM
Compound 3: only a limit was reported (the forecaster's own chance of this, stated with the estimate: 85%); the middle value does not contradict the limit.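

Within the data shown here, compound 2 and compound 3 each give only a limit in this assay, so no step between them can be read. The compounds shown leave open whether carboxy in place of methoxy on an aromatic carbon changes cytotoxicity at all, and at what concentration any of them would reach half-maximal inhibition.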